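The compounds below may be only part of what the source reports. "The series", "measured", "known", "first", "only" and "open" are said of these compounds alone.

Within the data shown here, compound 2, with the structure `O=C1CCCCC1S(=O)(=O)Nc1cc(C(F)(F)F)ccc1C(F)(F)F`, gives 95.7% in a functional assay on HL-60 cells (Homo sapiens) for antiproliferative activity, read by MTT assay, tested at 100 ug/mL (on this read-out lower numbers stand for less inhibition and higher numbers for more inhibition at the one concentration tested (going by the name of the read-out)), the highest of the three numbers measured so far. The nearest of the other two is compound 1, `O=C1CCCCC1S(=O)(=O)Nc1ccc(Cl)cc1C(F)(F)F`, which in this assay gives 78.6%, a gap beyond the usual scatter. The furthest is compound 3, `O=C1CCCCC1S(=O)(=O)Nc1ccc(Cl)c(Cl)c1`, which in this assay gives 13.5%, far below both. Among the measured compounds shown here, compound 3 is the only measured compound without a group on the aromatic carbon ortho to a large group, and it is also the one with the lowest number, though with three compounds no pattern can be claimed.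

Compound 4, `O=C1CCCCC1S(=O)(=O)Nc1cccc(C(F)(F)F)c1`, has not yet been measured. The difference from compound 2 is hydrogen in place of trifluoromethyl on an aromatic carbon, the carbon that loses the trifluoromethyl sitting ortho to a large group and para to a trifluoromethyl group. For the measured compounds named here, no step between measured compounds isolates this change, so the expected step has to be read off loosely from compound 3 with its 13.5% against compounds 1 and 2.

On that basis compound 4 is expected to lose a good part of the inhibition of compound 2, an estimated step of a number 50.7 percentage points lower from compound 2 to compound 4 (beyond the scatter). The estimate for compound 4 in this assay is 45%, within a range from 15% to 80%.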

Compound 4, a percentage reported as inhibition, at one concentration (the size of the read-out at that concentration, not a potency): 17%
For compound 4 the middle estimate is 28 percentage points above the measured one, within the range that was stated.
By their numbers in this assay, from the lowest: compounds 3 and 4 (each within the scatter of the next); then compound 1; then compound 2.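

In this assay, hydrogen in place of trifluoromethyl on the aromatic carbon ortho to a large group and para to a trifluoromethyl group gives a number 78.7 percentage points lower from compound 2 to compound 4 (beyond the scatter), a large step and the first among these compounds that isolates a single change. The trifluoromethyl group that remains in compound 4 does not by itself keep the number near that of compound 2, so the high inhibition of compound 2 at the one concentration tested depends on having the trifluoromethyl group at this place. Nothing in the data shown explains why this step is so large.

How a methyl group, a methoxy group, an amine or a carboxylic acid on this same carbon would compare with trifluoromethyl remains open, so the compounds shown cannot tell whether the step is specific to trifluoromethyl or would follow from any group there. Also open, going by these compounds, is whether a step of this size would hold with a different group in place of the remaining trifluoromethyl, and how it would look as a potency rather than as inhibition at one concentration.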